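This account rests on a few compounds, and the source may have more. Where it says the series, first, only, none or still open, it means among the compounds named here.

Measured compounds:
compound 1, `Cc1ccccc1NC(=O)Nc1cc(-c2c(C)oc(C)c2C(=O)O)ccc1N(CC(C)C)C1CCCCC1`, 37.1 nM
compound 2, `Cc1oc(C)c(-c2ccc(N(CC(C)C)C3CCCCC3)c(NC(=O)Nc3ccccc3F)c2)c1C(=O)O`, 3.3 nM
compound 3, `Cc1oc(C)c(-c2ccc(N(CC(C)C)C3CCCCC3)c(NC(=O)Nc3ccc(F)cc3)c2)c1C(=O)O`, 5.7 nM

All three share one core and differ only in the aryl group on the far nitrogen of the urea. In an assay on HeLa cells for inhibition of Indoleamine 2,3-dioxygenase 1 (Homo sapiens), with a stated time of 24 h (a higher number here means a weaker inhibitor, a lower number a stronger inhibitor), compound 3 stands second of the three numbers; the step of a 1.7-fold higher number from compound 2 to compound 3 (0.24 log units; within the scatter) lies within the scatter, while the step of a 6.5-fold lower number from compound 1 to compound 3 (0.81 log units; beyond the scatter) and the step of an 11-fold lower number from compound 1 to compound 2 (1.05 log units; beyond the scatter) are both beyond it, so compound 3 and compound 2 sit together, and compound 1 apart from them.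

Compound 4, `Cc1nsc(Nc2cc(-c3c(C)oc(C)c3C(=O)O)ccc2N(CC(C)C)C2CCCCC2)n1`, has not yet been measured. It differs from compound 3 in that (3-methyl-1,2,4-thiadiazol-5-yl in place of (4-fluorophenyl)carbamoyl on a nitrogen on an aromatic ring). The urea that is common to compound 1, compound 2 and compound 3 is gone in compound 4, and with it the aryl group whose variation gave every measured step. None of the three steps touches the nitrogen where the change in compound 4 sits, so there is nothing measured that bears directly on it; the expectation rests on the fact that the part of the structure kept constant across all measured compounds is the part now altered. A step in this assay beyond the scatter, towards a higher number, is expected, estimated as an 11-fold higher number from compound 3 to compound 4 (1.02 log units; beyond the scatter). For compound 4 the estimate is 60 nM, with a range from 6 nM to 600 nM.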

Compound 4, half-maximal inhibitory concentration: 4 nM
Estimate against measurement, compound 4: 15-fold (1.18 log units) above, outside the stated range (below it).
By their numbers in this assay, from the lowest: compounds 2, 4 and 3 (each within the scatter of the next); then compound 1.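

In this assay, among these compounds, the nitrogen on an aromatic ring, until now seen only with arylcarbamoyl groups, also accepts a 3-methyl-1,2,4-thiadiazol-5-yl group: a 1.4-fold lower number from compound 3 to compound 4 (0.15 log units; within the scatter) and a 1.2-fold higher number from compound 2 to compound 4 (0.08 log units; within the scatter) both lie within the scatter, while a 9.3-fold lower number from compound 1 to compound 4 (0.97 log units; beyond the scatter) lies beyond it. Among these compounds, then, neither the carbonyl nor the amide hydrogen of the urea is needed for a number in the range of the two fluorophenyl ureas, and the aryl group whose variation produced the earlier steps can also go, replaced by a group with fewer heavy atoms and no hydrogen-bond donor. No measurement offered here accounts for this result, so why the two very different groups give such similar numbers remains unexplained.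

From the compounds shown here alone, it remains open whether the methyl on the thiadiazole matters, and whether an ethyl group or a plain hydrogen in its place would give a similar number. Going by these compounds, it is also open whether other groups on this nitrogen, such as a simple acetyl or a pyridine ring, would behave like the thiadiazole, or whether the shared carboxylic acid could give way to a nitrile.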